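The source may hold more compounds than are shown below. What is called first, only, known or untested is meant among the compounds shown, and "the series" means these compounds.

Compound 2, `C#CCNC1CCc2c(SCCc3ccc(C)cc3)cccc21`, gives 25800 nM in an assay on isolated protein for inhibition of Amine oxidase [flavin-containing] B (Homo sapiens) (a higher number here means a weaker inhibitor, a lower number a stronger inhibitor), the highest of the three numbers recorded. Compound 1, `C#CCNC1CCc2c(OCc3cccc(C(F)(F)F)c3)cccc21`, gives 6410 nM in this assay, and compound 3, `C#CCNC1CCc2c(SCc3ccc(F)cc3F)cccc21`, gives 2430 nM; both of these stand lower than compound 2 by margins that lie beyond the scatter, so compound 2 is the weakest inhibitor among the three.

Compound 4, `C#CCNC1CCc2c(SCCc3cccc(Cl)c3)cccc21`, is the next compound to be measured in this assay. It differs from compound 2 in one place: 3-chlorophenyl in place of 4-methylphenyl on a saturated chain carbon, two bonds along the chain from a sulfur. Among the measured compounds shown here, no measured pair shows this exchange directly, so the expectation for compound 4 rests only on where compound 2 stands and on the size of the change. The step is expected to be small, at most a modest move toward a lower number, and may well fall within the scatter; the expected step is a 2.2-fold lower number from compound 2 to compound 4 (0.33 log units; beyond the scatter).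

Compound 4 is therefore estimated to give about 12000 nM in this assay, with a range from 4000 nM to 35000 nM.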

Compound 4, half-maximal inhibitory concentration: 82400 nM
Compound 4: middle estimate off by 6.9-fold (0.84 log units), on the low side; measured number outside the range, above it.
By their numbers in this assay, from the lowest: compound 3; then compound 1; then compound 2; then compound 4.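

Within this assay, the exchange of 4-methylphenyl for 3-chlorophenyl on the saturated chain gives a 3.2-fold higher number from compound 2 to compound 4 (0.50 log units; beyond the scatter), so this change makes the inhibitor modestly weaker rather than stronger. It is the first direct exchange shown at this position, and it shows that the aryl group on this chain affects the read-out even though the heavy-atom and hydrogen-bond counts of the two groups are the same. Nothing at hand explains the step.

The exchange alters both the ring substituent and its place on the ring, so the compounds shown do not separate the contribution of the chlorine from that of its location. Going by these compounds, a 4-chlorophenyl or 3-methylphenyl group on the same chain would separate the two, and how an unsubstituted phenyl group would stand remains open.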